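Fluoro to bromo on the cinnamamide ring of compound 3

This account rests on a few compounds, and the source may have more. Where it says the series, first, only, none or still open, it means among the compounds named here.

Measured compounds in an assay on isolated protein for displacement of a labelled ligand from melanin-concentrating hormone receptor 1 (Homo sapiens); a higher number here means a weaker inhibitor, a lower number a stronger inhibitor:
compound 1 `CCCc1ccc(/C=C/C(=O)Nc2ccc3nc(CCC)cc(N)c3c2)cc1` — compound 1 gives 4 nM
compound 2 `CCCc1cc(N)c2cc(NC(=O)/C=C/c3ccc(C(C)(C)C)cc3)ccc2n1` — compound 2 gives 22 nM
compound 3 `CCCc1cc(N)c2cc(NC(=O)/C=C/c3ccc(F)cc3)ccc2n1` — compound 3 gives 130 nM

Compound 3 stands highest of the three numbers in this assay. Its nearest neighbour is compound 2, separated by a 5.9-fold higher number from compound 2 to compound 3 (0.77 log units; beyond the scatter); compound 1 lies furthest away, with a 33-fold higher number from compound 1 to compound 3 (1.51 log units; beyond the scatter) between them. Between the two alkyl-bearing compounds the step is a 5.5-fold higher number from compound 1 to compound 2 (0.74 log units; beyond the scatter).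

Compound 4 `CCCc1cc(N)c2cc(NC(=O)/C=C/c3ccc(Br)cc3)ccc2n1` is the next member: bromo in place of fluoro on an aromatic carbon. Going by the values given here, no measured pair carries a bromo group, so the change has no direct precedent. What the data do show is that replacing fluoro on this carbon by propyl or tert-butyl lowers the number, modestly in a 5.9-fold higher number from compound 2 to compound 3 (0.77 log units; beyond the scatter) read backwards and substantially in a 33-fold higher number from compound 1 to compound 3 (1.51 log units; beyond the scatter) read backwards. Bromo is a single heavy atom at the same position, and no other element of the shared core changes.

On that basis the expected direction for compound 4 in this assay is downward, with a step of about a 3.3-fold lower number from compound 3 to compound 4 (0.51 log units; beyond the scatter). Compound 4 is thus estimated at 40 nM in this assay, with a range from 12 nM to 130 nM.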

Compound 4, half-maximal inhibitory concentration: 4 nM
Compound 4: middle estimate off by 10-fold (1.00 log units), on the high side, outside the stated range (below it).
By their numbers in this assay, from the lowest: compounds 1 and 4 (each within the scatter of the next); then compound 2; then compound 3.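

Going by these compounds alone, in (this assay), the earlier compounds only tied a lower number at this carbon to the alkyl groups propyl and tert-butyl, whereas a single bromo atom, para to a large group, now also gives a large step from fluoro (a 33-fold lower number from compound 3 to compound 4 (1.51 log units; beyond the scatter)). An alkyl chain is therefore not required at this carbon for the lowest numbers in the series: bromo matches propyl within the scatter (no change at the digits printed from compound 1 to compound 4 (within the scatter)) and stands apart from tert-butyl (a 5.5-fold lower number from compound 2 to compound 4 (0.74 log units; beyond the scatter)), so the two halogens sit at opposite ends of the values shown, with tert-butyl between them. Nothing available here explains why bromo and fluoro differ so widely at this carbon.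

As far as these compounds go, whether chloro or iodo on this carbon would read with bromo or with fluoro remains open, as does whether a longer chain such as butyl would keep the value seen with propyl. How methoxy, an amine or a carboxylic acid at the same carbon would behave in (this assay) is also unresolved.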